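An Ethylcarbamoyl Analogue of Compound 2

The source may report more compounds than this note shows. Statements on the series, on what has been measured and on what is new or still open speak of the compounds shown alone.

Compound 2 `CNC(=O)c1cc(Oc2ccc(NC(=O)c3cc4cccnc4n(-c4ccc(Cl)cc4)c3=O)cc2)ccn1` gives 370 nM in a functional assay on A549 cells (Homo sapiens) for antiproliferative activity, read by MTT assay, with a stated time of 72 h (a higher number here means a weaker inhibitor, a lower number a stronger inhibitor), and stands second highest of the three measured numbers. Compound 1 `CNC(=O)c1cc(Oc2ccc(NC(=O)c3cc4cccnc4n(-c4ccc(F)cc4)c3=O)cc2)ccn1` gives 110 nM, and the step of a 3.4-fold higher number from compound 1 to compound 2 (0.53 log units; beyond the scatter) is modest. Compound 3 `CNC(=O)c1cc(Oc2ccc(NC(=O)c3cc4cccnc4n(-c4ccc(Br)cc4F)c3=O)cc2)ccn1` gives 1420 nM, and the step of a 3.8-fold higher number from compound 2 to compound 3 (0.58 log units; beyond the scatter) is also modest. Compound 4 `CCNC(=O)c1cc(Oc2ccc(NC(=O)c3cc4cccnc4n(-c4ccc(Cl)cc4)c3=O)cc2)ccn1` differs from compound 2 by methyl in place of hydrogen on a saturated chain carbon bound to an amide-type nitrogen, the same difference reading methylcarbamoyl to ethylcarbamoyl. Among the compounds with values here, both measured steps alter the aryl group on the aromatic nitrogen; none alters the carbamoyl substituent, so no measured step bears directly on this change. The step of no change at the digits printed from compound 2 to compound 4 (within the scatter) is therefore expected to lie within the scatter, in neither direction. The estimate for compound 4 is 370 nM, with a range from 150 nM to 900 nM.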

Compound 4, half-maximal inhibitory concentration: 250 nM
Compound 4: the middle estimate sits 1.5-fold (0.17 log units) above what was measured, within the range that was stated.
By their numbers in this assay, from the lowest: compound 1; then compounds 4 and 2 (each within the scatter of the next); then compound 3.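

Within the data shown here, the carbamoyl substituent, unchanged among the earlier compounds, now has a step of its own: in this assay, methylcarbamoyl to ethylcarbamoyl gives a 1.5-fold lower number from compound 2 to compound 4 (0.17 log units; within the scatter). At this position, one added methyl stays within the scatter, whereas each measured step among the aryl groups on the aromatic nitrogen lay beyond it. Nothing available explains this result.

As far as these compounds go, whether a longer chain, a hydroxyethyl group or an amine in place of the ethyl would also stay within the scatter remains open. So does whether ethylcarbamoyl would behave the same with the 4-fluorophenyl group of compound 1.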